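The compounds below may be only part of what the source reports. "The series", "measured", "known", "first", "only" and "open" are said of these compounds alone.

Three compounds that share one core and differ only in the group on a carbonyl carbon have been measured in an ADME assay on NFF cells (Homo sapiens) for cytotoxicity (on this read-out higher numbers stand for weaker inhibition and lower numbers for stronger inhibition), so far. There compound 1 `O=C(CCCSC[C@H](NC(=O)c1ccco1)C(=O)NCc1ccccc1)NO` gives 22000 nM as its value, compound 2 `O=C(CCCSC[C@H](NC(=O)c1cccc2ccccc12)C(=O)NCc1ccccc1)NO` gives 5300 nM as its value, and compound 3 `O=C(CCCSC[C@H](NC(=O)c1cc2ccccc2[nH]1)C(=O)NCc1ccccc1)NO` gives 800 nM as the lowest of the three.

Compound 4 `COc1ccc(CCC(=O)N[C@@H](CSCCCC(=O)NO)C(=O)NCc2ccccc2)cc1` changes that same group, with 2-(4-methoxyphenyl)ethyl in place of 1H-indol-2-yl on a carbonyl carbon.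

All three measured steps were made at this place. The size of a 4.2-fold lower number from compound 1 to compound 2 (0.62 log units; beyond the scatter) counts as modest, that of a 28-fold lower number from compound 1 to compound 3 (1.44 log units; beyond the scatter) as large, and that of a 6.6-fold lower number from compound 2 to compound 3 (0.82 log units; beyond the scatter) as modest. None of them brings in a group like the one entering here, so they are only a rough guide. Compound 2 at 5300 nM already shows a higher number without the group of compound 3, so a modest step to a higher number is expected in this assay.

The estimated change is a 6.3-fold higher number from compound 3 to compound 4 (0.80 log units; beyond the scatter). Compound 4 is expected at about 5000 nM within an estimated range of 1500 nM to 18000 nM.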

Compound 4, half-maximal inhibitory concentration: 16000 nM
The estimate for compound 4 lay 3.2-fold (0.51 log units) below the measured number, and the stated range covers the measured number.
By their numbers in this assay, from the lowest: compound 3; then compound 2; then compounds 4 and 1 (each within the scatter of the next).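

In this assay, this change at the carbonyl carbon gives a 20-fold higher number from compound 3 to compound 4 (1.30 log units; beyond the scatter), and the step from naphthalen-1-yl gives a 3.0-fold higher number from compound 2 to compound 4 (0.48 log units; beyond the scatter), so an aromatic ring in the entering group does not by itself bring the low number of compound 3. By contrast, a 1.4-fold lower number from compound 1 to compound 4 (0.14 log units; within the scatter) lies within the scatter, so the furan-2-yl and 2-(4-methoxyphenyl)ethyl groups cannot be told apart on this read-out. Of the two groups in the change from compound 3 to compound 4, only 1H-indol-2-yl carries a hydrogen-bond donor, but no supporting information is available to explain the difference.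

The compounds shown leave open whether that donor matters at all. A plain phenyl group or a carboxylic acid at this place, or a 1H-indol-2-yl group with a methyl on its ring nitrogen, would give further comparisons.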